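The compounds below may be only part of what the source reports. "The series", "measured", "known", "first", "only" and "open" are said of these compounds alone.

In a functional assay on HeLa cells (Homo sapiens) for antiproliferative activity, read by MTT assay, with a stated time of 48 h (on this read-out lower numbers stand for stronger inhibition and higher numbers for weaker inhibition), compound 1 (`CCN(CC)CCn1c(N)c(-c2nc3ccccc3[nH]2)c2nc(C#N)c(C#N)nc21`) gives 11600 nM. Compound 2 (`CCCn1c(N)c(-c2nc3ccccc3[nH]2)c2nc(C#N)c(C#N)nc21`) gives > 50000 nM, which is a limit of the assay and not a number. Compound 3 (`N#Cc1nc2c(-c3nc4ccccc4[nH]3)c(N)n(CCO)c2nc1C#N`) keeps the shared core and has hydroxy in place of methyl on a saturated chain carbon, two bonds along the chain from an aromatic nitrogen. In other words, propyl becomes 2-hydroxyethyl. For the measured compounds named here, only one measured step touches this place. It is an at least 4.3-fold higher number from compound 1 to compound 2 (0.63 log units; beyond the scatter), where methyl replaced diethylamino, and it ends at the limit (the limit of > 50000 nM in this assay, at which 1 of the 2 values shown sits). Hydroxy is a different group from diethylamino, so this step is only a rough guide. A modest move towards a lower number is expected, though a second limit would be no surprise: an at least 1.4-fold lower number from compound 2 to compound 3 (0.15 log units; that floor lies within the scatter). For compound 3, the estimated value is 35000 nM, with an expected range from 12000 nM to 90000 nM.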

Compound 3, half-maximal inhibitory concentration: > 50000 nM
Compound 3: no number, only a limit; the forecaster's own chance of this, stated with the estimate: 50%; middle value at least 1.4-fold (0.15 log units) from the limit.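

In this assay, replacing diethylamino with hydroxy gives an at least 4.3-fold higher number from compound 1 to compound 3 (0.63 log units; beyond the scatter). Compound 3 therefore joins compound 2 in losing the measurable activity of compound 1, so two different replacements for diethylamino, methyl and hydroxy, now point the same way at this position. The step from compound 2 to compound 3 cannot be read, and hydroxy cannot be ranked against methyl, because both compounds sit at a limit of the assay rather than at a number: the limit of > 50000 nM in this assay, at which 2 of the 3 values shown sit.

For the compounds shown here, compound 1 is the only compound here with a real number, so a single amine-bearing chain carries all the evidence for this position. From the compounds shown here alone, whether a smaller amine such as dimethylamino, a ring amine such as morpholine, or a longer chain ending in diethylamino would keep or improve that activity remains open.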